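The source may hold more compounds than are shown below. What is called first, only, known or untested is meant among the compounds shown, and "the series" means these compounds.

Of the compounds shown here, two have been tested so far in a toxicity assay on HeLa cells (Homo sapiens) for cytotoxicity; a lower number here means that less compound is tolerated, a higher number that more compound is tolerated. Compound 1, with the structure `COc1ncc(-c2ccccc2)cc1[C@@H](c1ccccc1)[C@@](O)(CCN(C)C)c1cc(F)cc(F)c1`, gives 28.8 ug/mL in this assay. Compound 2, with the structure `COc1nc(-c2ccncc2)ccc1[C@@H](c1ccccc1)[C@@](O)(CCN(C)C)c1cccc2ccccc12`, gives 9.6 ug/mL in this assay. Compound 2 therefore stands at the lowest of the two numbers; the number for compound 1 is higher, and the gap between them is beyond the usual scatter of repeated measurements, so less of compound 2 is tolerated by the cells than of compound 1.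

The next compound is compound 3, with the structure `COc1nc(-c2cccc(F)c2)ccc1[C@@H](c1ccccc1)[C@@](O)(CCN(C)C)c1cccc2ccccc12`. It is built from compound 2 by one change: 3-fluorophenyl in place of pyridin-4-yl on an aromatic carbon. For the measured compounds named here, no measured pair of compounds shows this kind of change, so there is no step to lean on. The expected step from compound 2 to compound 3 is a 1.2-fold lower number from compound 2 to compound 3 (0.08 log units; within the scatter), small and not clearly beyond the scatter. Compound 3 is therefore estimated at 8 ug/mL, within the range 4 ug/mL to 16 ug/mL.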

Compound 3, half-maximal cytotoxic concentration: 62.8 ug/mL
Beside the measured number, compound 3's estimate is 7.9-fold (0.89 log units) below it; measured number outside the range, above it.
By their numbers in this assay, from the lowest: compound 2; then compound 1; then compound 3.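

In this assay, putting 3-fluorophenyl in place of pyridin-4-yl on the aromatic carbon next to the ring nitrogen gives a 6.5-fold higher number from compound 2 to compound 3 (0.82 log units; beyond the scatter). This position is therefore not indifferent to what it carries, even when one six-membered aromatic ring replaces another of nearly the same size. Nothing available explains why the number moves this far.

The swap removes a ring nitrogen and adds a fluorine at once, so this single pair cannot show which of the two accounts for the step. Going by these compounds, whether the higher number holds for other groups at this place, such as pyridin-3-yl, an amine or a carboxylic acid, remains open.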